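Halogen swap on the distal phenyl ring: chloro to fluoro

The compounds below may be only part of what the source reports. "The series", "measured", "known", "first", "only" and "open" are said of these compounds alone.

Of the compounds shown here, two have been measured in a functional assay on IGROV-1 cells (Homo sapiens) for inhibition, read by sulforhodamine B assay, with a stated time of 48 h; on this read-out higher numbers stand for weaker inhibition of growth and lower numbers for stronger inhibition of growth. Compound 1 `N=C(N)c1ccc(-c2ccc(-c3cc(Cl)cc(Cl)c3)s2)s1` gives 1970 nM in this assay. Compound 2 `N=C(N)c1ccc(-c2ccc(-c3ccc(Cl)cc3)s2)s1` gives 1830 nM in this assay; the two numbers lie within the usual scatter of each other, so compound 2 stands level with compound 1 rather than apart from it, and neither can be called the more active of the pair.

Compound 3 `N=C(N)c1ccc(-c2ccc(-c3ccc(F)cc3)s2)s1` differs from compound 2 in one place: fluoro in place of chloro on an aromatic carbon. Among the measured compounds shown here, no step between measured compounds is available to set a size for this change, and neither compound 1 nor compound 2 carries fluoro. The expectation is a small shift in this assay toward weaker inhibition, at or just beyond the scatter, written as a 1.4-fold higher number from compound 2 to compound 3 (0.15 log units; within the scatter). On this basis compound 3 is estimated at 2600 nM in this assay, with a range from 1200 nM to 5600 nM.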

Compound 3, concentration for 50% growth inhibition: 1730 nM
Estimate against measurement, compound 3: 1.5-fold (0.18 log units) above; low and high end bracket the measured number.
By their numbers in this assay, from the lowest: compounds 3, 2 and 1 (each within the scatter of the next).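

In this assay, fluoro in place of chloro on the aromatic carbon para to a large group gives a 1.1-fold lower number from compound 2 to compound 3 (0.02 log units; within the scatter). Among the compounds shown here, this is the first step between measured compounds at this position, and it shows that this exchange of one halogen for the other leaves no readable difference in growth inhibition. No supporting data on the compounds bear on this result.

Going by these compounds, the step covers only these two halogens, so whether the result holds with an amine, a hydroxyl or a carboxylic acid at the same place stays open. Also open, on these data alone, is whether the same exchange would read the same way on other cell lines.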